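The source may hold more compounds than are shown below. What is called first, only, known or untested is meant among the compounds shown, and "the series" means these compounds.

Three compounds on one shared core, differing in the group on an aromatic carbon, have been tested in a functional assay on NALM-6 cells (Homo sapiens) for cytotoxicity, with a stated time of 72 h; a higher number here means that more compound is needed for the effect, a lower number that less compound is needed. Compound 1 `C=C[C@@](C)(/C=C/c1ccc(O)c(C=O)c1)CCC=C(C)C`, which carries formyl there, gives 11200 nM. Compound 2 `C=C[C@@](C)(/C=C/c1ccc(O)c(/C=C/C#N)c1)CCC=C(C)C`, which carries 2-cyanoethenyl, gives > 43400 nM, and this is a limit of the assay, not a number. Compound 3 `C=C[C@@](C)(/C=C/c1ccc(O)c(/C=C(\C)C(=O)OCC)c1)CCC=C(C)C`, which carries 2-(ethoxycarbonyl)prop-1-en-1-yl, gives > 7500 nM, and this too is only a limit. Compound 2 therefore has no exact position, although an at least 3.8-fold higher number from compound 1 to compound 2 (0.58 log units; beyond the scatter) is a step beyond the scatter. The other two steps, a step that the limit leaves unreadable from compound 1 to compound 3 and a step that the two limits leave unreadable from compound 2 to compound 3, cannot be sized.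

Compound 4 `C=C[C@@](C)(/C=C/c1ccc(O)c(/C=C/c2ccc(Cl)c(Cl)c2)c1)CCC=C(C)C` changes the end of the chain in compound 2: 3,4-dichlorophenyl in place of cyano on a double-bonded chain carbon bound to a double-bonded chain carbon. Among the measured compounds shown here, no measured step brings in an aromatic ring at this place, so the guidance is weak. For the measured compounds named here, the only exact number belongs to compound 1, at 11200 nM, so the expectation for compound 4 is anchored near that value, with a wide margin. A lower number than the limit of compound 2 is therefore expected, and the size of the step is uncertain. The expected step is an at least 3.6-fold lower number from compound 2 to compound 4 (0.55 log units; beyond the scatter). For compound 4 the estimated value is 12000 nM, with an expected range from 4000 nM to 40000 nM.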

Compound 4, half-maximal effective concentration: 7510 nM
Compound 4: middle estimate off by 1.6-fold (0.20 log units), on the high side; the range from low to high includes it.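

Putting 3,4-dichlorophenyl in place of cyano on a double-bonded chain carbon bound to a double-bonded chain carbon gives an at least 5.7-fold lower number from compound 2 to compound 4 (0.76 log units; beyond the scatter) in this assay. This shows that the number at this place responds to what stands at the end of the chain, and that a group of 8 heavy atoms with an aromatic ring still gives a measurable effect where cyano, with 2 heavy atoms, did not. The step gives only a smallest possible size, not an exact one, because compound 2 has no exact value: the limit of > 43400 nM in this assay, at which 1 of the 4 values shown sits.

The ring and its two chlorines enter together, so the compounds shown cannot separate their contributions, and a plain phenyl ring, a 4-chlorophenyl ring or an amine at the same place would each test a different part of the change. The steps that reach compound 3 cannot be read, and its value is only a limit: the limit of > 7500 nM in this assay, at which 1 of the 4 values shown sits.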